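Working notes: a new group on the sulfonyl sulfur

A few compounds are considered here, and "the series" means these few. Any claim that something is new, unique, unknown or untested is made for them only; others in the source may bear on it.

Among the measured compounds shown here, in a physicochemical assay for solubility, in phosphate buffer, with a stated time of 24 h, at pH 7.4, tested at 100 uM (a lower number here means a less soluble compound, a higher number a more soluble compound), compound 1 (`O=C(NCc1ccc(S(=O)(=O)c2cccc(C(F)(F)F)c2)cc1)N1Cc2ccncc2C1`) gives 10000 nM and compound 2 (`O=C(NCc1ccc(S(=O)(=O)N2CCC[C@@H](O)C2)cc1)N1Cc2ccncc2C1`) gives 216000 nM, the higher of the two numbers so far. Compound 3 (`O=C(NCc1ccc(S(=O)(=O)N2CC3(CCOCC3)C2)cc1)N1Cc2ccncc2C1`) keeps the shared core and changes the same place: a group of 9 heavy atoms (7 carbon, 1 nitrogen, 1 oxygen; one four-membered non-aromatic ring with 1 hetero atom, one six-membered non-aromatic ring with 1 hetero atom) in place of a group of 7 heavy atoms (5 carbon, 1 nitrogen, 1 oxygen; one six-membered non-aromatic ring with 1 hetero atom), on a sulfonyl sulfur. For the measured compounds named here, the only measured step bearing on this is large: a 22-fold higher number from compound 1 to compound 2 (1.33 log units; beyond the scatter), with 3-hydroxypiperidin-1-yl in place of 3-(trifluoromethyl)phenyl on a sulfonyl sulfur. Going by the values given here, the entering group, like the one in compound 2, holds only non-aromatic rings, so that step is a loose guide. Among the compounds with values here, no measured step compares two non-aromatic groups. A modest fall in this assay is expected, much smaller than the earlier step: a 2.4-fold lower number from compound 2 to compound 3 (0.38 log units; beyond the scatter). For compound 3 the estimated value is 90000 nM, with an expected range of 30000 nM to 220000 nM.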

Compound 3, solubility: 272000 nM
Compound 3: middle estimate off by 3.0-fold (0.48 log units), on the low side; measured number outside the range, above it.
By their numbers in this assay, from the lowest: compound 1; then compounds 2 and 3 (each within the scatter of the next).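

In this assay the second non-aromatic group on the sulfonyl sulfur gives a 1.3-fold higher number from compound 2 to compound 3 (0.10 log units; within the scatter) and so stands within the scatter of 3-hydroxypiperidin-1-yl, although it carries 0 hydrogen-bond donors and no defined stereocentre where that group carries 1 of each. Against the 3-(trifluoromethyl)phenyl group of compound 1 the new group again gives a large step, a 27-fold higher number from compound 1 to compound 3 (1.43 log units; beyond the scatter) and the large step at this position is therefore not tied to 3-hydroxypiperidin-1-yl alone. No supporting data are available to explain either step.

Still open, going by these compounds, is whether the large step goes with the loss of the aromatic ring or of the trifluoromethyl group, which an unsubstituted phenyl on the sulfonyl sulfur would separate. Also open, on these data alone, is how an open-chain dimethylamino group or a piperazine would read at this position.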